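Pyridine for Pyrazine on a Shared Diamide Core

This account rests on a few compounds, and the source may have more. Where it says the series, first, only, none or still open, it means among the compounds named here.

Going by the values given here, compound 1 `O=C(N[C@H]1CCC[C@H](NC(=O)c2cnccn2)C1)c1cccc(Cl)c1` is the only member of this small set with a measured number: in a functional assay on HEK293 cells for antagonist activity at metabotropic glutamate receptor 5 (Homo sapiens), read by FLIPR and calcium flux (on this read-out lower numbers stand for stronger inhibition and higher numbers for weaker inhibition), compound 1 gives 1370 nM. Compound 2 `N#Cc1cccc(C(=O)N[C@@H]2CCC[C@H](NC(=O)c3ccccn3)C2)c1` reaches only a limit of the assay, > 10000 nM in this assay. Compound 3 `N#Cc1cccc(C(=O)N[C@H]2CCC[C@H](NC(=O)c3ccccn3)C2)c1` likewise reaches only the limit > 10000 nM. The step that the two limits leave unreadable from compound 2 to compound 3 therefore cannot be read; the two compounds differ only in configuration as drawn (the fact that compounds 2 and 3 differ only in the configuration as drawn), and both sit at the limit of > 10000 nM in this assay, at which 2 of the 3 values shown sit.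

Compound 4 `O=C(N[C@H]1CCC[C@H](NC(=O)c2ccccn2)C1)c1cccc(Cl)c1` differs from compound 1 in one place: pyridin-2-yl in place of pyrazin-2-yl on a carbonyl carbon. Among the compounds with values here, no measured step covers this exchange. Compounds 2 and 3 carry the pyridin-2-yl group that enters, but they carry a nitrile where compound 1 carries a chlorine, so their limits say nothing direct about the pyrazine-to-pyridine change itself. The expectation for compound 4 therefore rests on compound 1 alone, with wide bounds. The estimate for compound 4 in this assay is 2500 nM, between 700 nM and 10000 nM. The expected step of a 1.8-fold higher number from compound 1 to compound 4 (0.26 log units; within the scatter) is expected to be small, within or close to the scatter, with a real chance that compound 4 returns only a limit.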

Compound 4, half-maximal inhibitory concentration: > 10000 nM
Compound 4: no number, only a limit; the forecaster's own chance of this, stated with the estimate: 30%; middle value at least 4.0-fold (0.60 log units) from the limit.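

In this assay, putting pyridin-2-yl in place of pyrazin-2-yl on a carbonyl carbon gives an at least 7.2-fold higher number from compound 1 to compound 4 (0.86 log units; beyond the scatter), so this position of the shared core is not indifferent to the exchange. Compound 4 gives only a limit of the assay, > 10000 nM, so the step has a floor but no readable upper end. The earlier compounds carried pyridin-2-yl only together with a nitrile; with the chlorine kept, the exchange now stands alone, and every pyridin-2-yl compound shown lies at the same limit: the limit of > 10000 nM in this assay, at which 3 of the 4 values shown sit.

The steps from compound 2 to compound 3 and from compound 3 to compound 4 cannot be read, as each joins two limits, so neither the configuration nor the exchange of chloro for cyano can be judged among the pyridin-2-yl compounds. Also open, from the compounds shown here alone, is how a pyrimidin-2-yl or a phenyl group on the same carbonyl carbon would read, and where a nitrile would place a compound that keeps pyrazin-2-yl.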